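Series notes: ester exchange at a second carbonyl

A few compounds are considered here, and "the series" means these few. Any claim that something is new, unique, unknown or untested is made for them only; others in the source may bear on it.

Three members of the series have numbers in a functional assay on NCI/ADR-RES cells (Homo sapiens) for positive allosteric modulation, read by MTT assay, with a stated time of 48 h, tested at 10 uM; on this read-out lower numbers stand for stronger inhibition and higher numbers for weaker inhibition. Compound 1 `C=C1[C@H](OC(C)=O)[C@@H](OC(=O)C(C)(C)C)[C@@H](OC(C)=O)C(C)(C)/C=C/[C@H](C)[C@H](OC(=O)c2ccccc2)[C@@]2(O)C[C@@](C)(OC(C)=O)[C@H](OC(C)=O)[C@@H]2[C@H]1OCC(C)C` gives 1730 nM, compound 2 `C=C1[C@H](OC(C)=O)[C@@H](OC(=O)c2cccc(C)c2)[C@@H](OC(C)=O)C(C)(C)/C=C/[C@H](C)[C@H](OC(=O)c2ccccc2)[C@@]2(O)C[C@@](C)(OC(C)=O)[C@H](OC(C)=O)[C@@H]2[C@H]1OCC(C)C` gives 1920 nM, and compound 3 `C=C1[C@H](OC(C)=O)[C@@H](OC(C)=O)[C@@H](OC(C)=O)C(C)(C)/C=C/[C@H](C)[C@H](OC(=O)c2ccccc2)[C@@]2(O)C[C@@](C)(OC(C)=O)[C@H](OC(C)=O)[C@@H]2[C@H]1OCC(C)C` gives 4810 nM, the highest number of the three. The steps of a 1.1-fold higher number from compound 1 to compound 2 (0.05 log units; within the scatter) and a 2.8-fold higher number from compound 1 to compound 3 (0.44 log units; beyond the scatter) and a 2.5-fold higher number from compound 2 to compound 3 (0.40 log units; beyond the scatter) show that, at the carbonyl carbon varied there, the tert-butyl and 3-methylphenyl esters sit together and the acetate stands apart.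

Compound 4 `C=C1[C@H](OC(C)=O)[C@@H](OC(C)=O)[C@@H](OC(C)=O)C(C)(C)/C=C/[C@H](C)[C@H](OC(=O)c2ccccc2)[C@@]2(O)C[C@@](C)(OC(=O)c3cccc(C)c3)[C@H](OC(C)=O)[C@@H]2[C@H]1OCC(C)C` differs from compound 3 by 3-methylphenyl in place of methyl on a carbonyl carbon. Going by the values given here, the same pair of groups is exchanged as in the step from compound 2 to compound 3, but, as the structures show, not at the same carbonyl carbon; no measured step speaks directly to this ester. Taking the step of a 2.5-fold higher number from compound 2 to compound 3 (0.40 log units; beyond the scatter) in reverse as the only guide, a modest lower number is expected in this assay, with wide uncertainty because the site of the exchange is new. Compound 4 is therefore estimated at 2600 nM, between 1200 nM and 5800 nM, a step of a 1.9-fold lower number from compound 3 to compound 4 (0.27 log units; within the scatter).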

Compound 4, half-maximal inhibitory concentration: 1510 nM
For compound 4 the middle estimate is 1.7-fold (0.24 log units) above the measured one; measured number inside the range.
By their numbers in this assay, from the lowest: compounds 4, 1 and 2 (each within the scatter of the next); then compound 3.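

In this assay the acetate at this carbonyl carbon also responds to exchange, with a 3.2-fold lower number from compound 3 to compound 4 (0.50 log units; beyond the scatter) as 3-methylphenyl replaces methyl. The earlier compounds shown here spoke only to the other carbonyl carbon, where a 2.5-fold higher number from compound 2 to compound 3 (0.40 log units; beyond the scatter) shows the same exchange in reverse, so in these two pairs the acetate carries the higher number at both sites. Nothing available accounts for the step at this carbonyl carbon.

The compounds shown leave open whether tert-butyl, which sits with 3-methylphenyl at the other carbonyl carbon, would do the same here, and whether an unsubstituted phenyl, a longer chain or an amine-bearing ester would follow. Also open, on these data alone, is how the core would read with 3-methylphenyl esters on both carbonyl carbons in one molecule.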